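The compounds below may be only part of what the source reports. "The series", "measured", "known", "first", "only" and "open" are said of these compounds alone.

Of the compounds shown here, three that share one core have been tested in a functional assay on SW-620 cells (Homo sapiens) for cytotoxicity, read by MTT assay, with stated times of 4 h and 72 h, tested at 5 uM; a lower number here means a stronger inhibitor, a higher number a weaker inhibitor. Compound 1 `Cc1cc(Nc2ccc(C(=O)/C=C/c3ccc4ccccc4c3)cc2)n2nc(SCc3ccc(Cl)cc3)nc2n1` gives 570 nM. Compound 2 `Cc1cc(Nc2ccc(C(=O)/C=C/c3ccc4ccccc4c3)cc2)n2nc(SCc3cccc(C(F)(F)F)c3)nc2n1` gives 2070 nM. Compound 3 `Cc1ccc(CSc2nc3nc(C)cc(Nc4ccc(C(=O)/C=C/c5ccc6ccccc6c5)cc4)n3n2)cc1` gives 880 nM. On these numbers compound 3 stands second highest of the three: its nearest neighbour is reached by a 1.5-fold higher number from compound 1 to compound 3 (0.19 log units; within the scatter), and its furthest by a 2.4-fold lower number from compound 2 to compound 3 (0.37 log units; beyond the scatter).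

Compound 4 `Cc1cc(Nc2ccc(C(=O)/C=C/c3ccc4ccccc4c3)cc2)n2nc(SCc3ccccc3Br)nc2n1` has not yet been measured. Its difference from compound 3 is this: 2-bromophenyl in place of 4-methylphenyl on a saturated chain carbon bound to a sulfur. Among the compounds with values here, two measured steps bear on it. Changing the ring on the saturated chain carbon bound to a sulfur has moved the number once, in a 3.6-fold higher number from compound 1 to compound 2 (0.56 log units; beyond the scatter), a modest step. Swapping methyl for chloro on that same ring gave a 1.5-fold higher number from compound 1 to compound 3 (0.19 log units; within the scatter), which stayed within the scatter. Compound 4 carries a bromine on that ring, so the change resembles the step from compound 3 back toward compound 1 more than the step toward compound 2. The expected step is therefore small, a 1.3-fold lower number from compound 3 to compound 4 (0.10 log units; within the scatter), leaning toward a lower number, with no step beyond the scatter being the likeliest outcome. For compound 4 the estimate in this assay is 700 nM, expected to fall between 300 nM and 1700 nM.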

Compound 4, half-maximal inhibitory concentration: 420 nM
Beside the measured number, compound 4's estimate is 1.7-fold (0.22 log units) above it; low and high end bracket the measured number.
By their numbers in this assay, from the lowest: compounds 4, 1 and 3 (each within the scatter of the next, the first and the last beyond it); then compound 2.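

In this assay, the ring on the saturated chain carbon bound to a sulfur can take a 2-bromophenyl group, and this swap gives a 2.1-fold lower number from compound 3 to compound 4 (0.32 log units; beyond the scatter), so replacing 4-methylphenyl has an effect that exceeds the usual variation between repeat measurements. The same group gives a 1.4-fold lower number from compound 1 to compound 4 (0.13 log units; within the scatter), so 2-bromophenyl and 4-chlorophenyl cannot be told apart here, even though the substituent differs in both identity and place on the ring, while a 4.9-fold lower number from compound 2 to compound 4 (0.69 log units; beyond the scatter) is the widest step yet seen at this position and confirms compound 2 as the weakest of the four. No measurement on hand explains why these rings differ, so the numbers record the size of each change and give no cause for it.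

Each ring swap so far changes the substituent and its place together, so a 4-bromophenyl group would be needed to separate the bromine itself from where it sits. On these data alone, how an unsubstituted phenyl, a ring carrying an amine or a carboxylic acid, or a longer chain in place of the single chain carbon would read in this assay also remains open.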